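This account rests on a few compounds, and the source may have more. Where it says the series, first, only, none or still open, it means among the compounds named here.

Compounds measured in a functional assay on CHO-K1 cells for agonist activity at Glucose-dependent insulinotropic receptor (Mus musculus), read by HTRF and cAMP accumulation, with a stated time of 30 min; a lower number here means a smaller maximal response, a higher number a larger maximal response:

Compound 1, `CCc1cnc(N2CCC(CCCNc3ccc4c(c3)C(=O)CC4)CC2)nc1`, gives 110%.
Compound 2, `CC(C)(C)OC(=O)N1CCC(CCCNc2ccc3c(c2)C(=O)CC3)CC1`, gives 110%.
Compound 3, `COc1cnc(N2CCC(CCCNc3ccc4c(c3)OCC4=O)CC2)nc1`, gives 106%.

In this assay compound 2 sits level with compound 1 at the digits shown; compound 3 lies a few points lower, and all three values fall within the scatter of one another, so no compound can be set apart from the others.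

The change followed here leads from compound 2 to compound 4, `CC(C)c1noc(N2CCC(CCCNc3ccc4c(c3)C(=O)CC4)CC2)n1`. The difference is 3-isopropyl-1,2,4-oxadiazol-5-yl in place of tert-butoxycarbonyl on an amine nitrogen in a ring. For the measured compounds named here, one measured step bears on it: the step of no change at the digits printed from compound 1 to compound 2 (within the scatter), which also exchanged the group on that same ring amine nitrogen, and it brought no change beyond the scatter. Compound 3, which carries a different group on the same nitrogen and a different core, also stays within the scatter of compounds 1 and 2. Among the compounds measured, the group on this nitrogen has therefore not been seen to move the maximal response. On that basis the step from compound 2 to compound 4 is expected to be a number 2 percentage points lower from compound 2 to compound 4 (within the scatter), that is, no change beyond the scatter. Compound 4 is accordingly estimated at 108%, with a range from 97% to 119%.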

Compound 4, largest response reached (Emax), in percent of the reference or control that the assay uses: 113%
Estimate against measurement, compound 4: 5 percentage points below; measured number inside the range.
By their numbers in this assay, from the lowest: compounds 3, 1, 2 and 4 (each within the scatter of the next).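

In this assay, 3-isopropyl-1,2,4-oxadiazol-5-yl in place of tert-butoxycarbonyl gives a number 3 percentage points higher from compound 2 to compound 4 (within the scatter), and the same group in place of 5-ethylpyrimidin-2-yl gives a number 3 percentage points higher from compound 1 to compound 4 (within the scatter). The amine nitrogen in the ring has thus now carried three different groups on one shared core, including a five-membered aromatic ring with 3 hetero atoms, and the maximal response stays within the scatter across all of them, so this position shows the same insensitivity with a third type of group. No measurement shown here accounts for this lack of effect on the maximal response.

From the compounds shown here alone, it remains open whether any group on this nitrogen can lower the maximal response, as all three groups compared here leave it within the scatter, and a bare ring amine, a small acetyl group or a group bearing a carboxylic acid could test that limit. Because only the maximal response is given, these compounds also leave open whether the exchange alters the concentration needed to reach it, and whether a shorter or longer chain in place of the propyl linker would behave the same way.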